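Replacing 3,5-difluorophenyl in compound 3 with benzofuran

The source may hold more compounds than are shown below. What is called first, only, known or untested is meant among the compounds shown, and "the series" means these compounds.

In an ADME assay on MRC5 cells (Homo sapiens) for inhibition, with a stated time of 72 h (a higher number here means that more compound is needed for the effect, a lower number that less compound is needed), compound 1 (`CO[C@H]1CC[C@H](NC(=O)c2n[nH]cc2NC(=O)c2ccccc2F)CC1`) gives 1000 nM, compound 2 (`COc1ccccc1C(=O)Nc1c[nH]nc1C(=O)N[C@H]1CC[C@H](OC)CC1`) gives 1500 nM and compound 3 (`CO[C@H]1CC[C@H](NC(=O)c2n[nH]cc2NC(=O)c2cc(F)cc(F)c2)CC1`) gives 600 nM. Compound 3 stands within the scatter of compound 1 and apart from compound 2 only.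

Compound 4 (`CO[C@H]1CC[C@H](NC(=O)c2n[nH]cc2NC(=O)c2cc3ccccc3o2)CC1`) carries 1-benzofuran-2-yl in place of 3,5-difluorophenyl on a carbonyl carbon.

Three measured changes at this carbonyl carbon bear on it: a 1.5-fold higher number from compound 1 to compound 2 (0.18 log units; within the scatter), a 1.7-fold lower number from compound 1 to compound 3 (0.22 log units; within the scatter) and a 2.5-fold lower number from compound 2 to compound 3 (0.40 log units; beyond the scatter). The last is the only one beyond the scatter, and none of the three involves a benzofuran. No clear shift is therefore expected in this assay. The estimated step is a 1.2-fold lower number from compound 3 to compound 4 (0.08 log units; within the scatter). Compound 4 is estimated at 500 nM, with an expected range of 170 nM to 1500 nM.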

Compound 4, half-maximal effective concentration: 800 nM
Estimate against measurement, compound 4: 1.6-fold (0.20 log units) below; the measured number falls inside the stated range.
By their numbers in this assay, from the lowest: compounds 3, 4, 1 and 2 (each within the scatter of the next, the first and the last beyond it).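

In this assay, for the compounds shown here, the carbonyl carbon accepts 1-benzofuran-2-yl, the only group here with a five-membered aromatic ring, with a 1.3-fold higher number from compound 3 to compound 4 (0.12 log units; within the scatter) and a 1.3-fold lower number from compound 1 to compound 4 (0.10 log units; within the scatter) as the steps. The 2-methoxyphenyl comparison also stays inside the scatter for this group, with a 1.9-fold lower number from compound 2 to compound 4 (0.27 log units; within the scatter) as the step, whereas the corresponding step for 3,5-difluorophenyl lay beyond it. No supporting data explain these steps.

Still open, on these data alone, is whether an amine or a carboxylic acid on this carbonyl carbon would give a step beyond the scatter from compound 4.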